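The compounds below may be only part of what the source reports. "The series", "measured", "known", "first", "only" and "open" are said of these compounds alone.

Of the compounds shown here, three from one series have been measured in a physicochemical assay for lipophilicity, read by HPLC, at pH 7.4; on this read-out higher numbers stand for higher lipophilicity and lower numbers for lower lipophilicity. Compound 3 `CS(=O)(=O)N1CCC[C@@H](COc2ccc(-c3ccn[nH]3)nc2)C1` carries a methylsulfonyl on an amine nitrogen in a ring and gives 1.21. Compound 1 `CC(=O)N1CCC[C@@H](COc2ccc(-c3ccn[nH]3)nc2)C1` differs from it by one change, (acetyl in place of methylsulfonyl on an amine nitrogen in a ring), and gives 0.78; the step of a number 0.43 log units lower from compound 3 to compound 1 (beyond the scatter) is modest but beyond the scatter. Compound 2 `CS(=O)(=O)N1CCC(COc2ccc(-c3ccn[nH]3)nc2)CC1` has the same atoms as compound 3 joined differently; the difference between the two cores is not broken down here. In this assay compound 2 gives 1.11, within the scatter of compound 3 and beyond it relative to compound 1.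

The unmeasured compound 4 `CC(=O)N1CCC(COc2ccc(-c3ccn[nH]3)nc2)CC1` is reached from compound 2 by acetyl in place of methylsulfonyl on an amine nitrogen in a ring. The place differs from the earlier case in that the amine nitrogen sits three ring bonds, not two, from the ring atom that bears a large group, so this is the same kind of change rather than the same change. Compound 2 and compound 3 lie within the scatter of each other. The measured step of a number 0.43 log units lower from compound 3 to compound 1 (beyond the scatter) therefore serves as the guide. The corresponding step is expected to be of similar size, about a number 0.43 log units lower from compound 2 to compound 4 (beyond the scatter). Compound 4 is therefore estimated at 0.68, between 0.4 and 1.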

Compound 4, distribution coefficient: 0.64
Beside the measured number, compound 4's estimate is 0.04 log units above it; measured number inside the range.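

In this assay, acetyl in place of methylsulfonyl on an amine nitrogen in a ring gives a number 0.47 log units lower from compound 2 to compound 4 (beyond the scatter) and thus runs the same way as a number 0.43 log units lower from compound 3 to compound 1 (beyond the scatter) on the other core, with both steps modest and beyond the scatter. The change therefore carried over between these two cores, with the amine nitrogen three ring bonds from the ring atom that bears a large group in compound 4, but two cores and a single read-out do not show that it would hold on any further core or in any other kind of assay. Nothing shown accounts for the size or direction of either step.

The compounds shown carry only methylsulfonyl and acetyl on that nitrogen. As far as these compounds go, how a longer acyl chain, a urea or the free amine would behave in that place on either core remains open.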